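The source may hold more compounds than are shown below. What is called first, only, known or untested is meant among the compounds shown, and "the series" means these compounds.

Three compounds share one core and differ only in the saturated ring attached to the chain carbon bound to the sulfonamide nitrogen. Compound 1 `CC1(C)C[C@@H](CN([C@H](CCC(F)(F)F)C(N)=O)S(=O)(=O)c2ccc(Cl)cc2)O1` gives 14.9 10^-6 cm/s in an ADME assay on MDCKII-LE cells (Canis lupus familiaris) for permeability, read by transwell migration, in the apical to basolateral direction; on this read-out lower numbers stand for lower permeability and higher numbers for higher permeability. Compound 2 `CC1(C)CO[C@@H]1CN([C@H](CCC(F)(F)F)C(N)=O)S(=O)(=O)c1ccc(Cl)cc1` gives 22.3 10^-6 cm/s, and compound 3 `NC(=O)[C@@H](CCC(F)(F)F)N(C[C@H]1CCCCO1)S(=O)(=O)c1ccc(Cl)cc1` gives 13.4 10^-6 cm/s. These three numbers lie within the scatter of one another: a 1.5-fold higher number from compound 1 to compound 2 (0.18 log units; within the scatter), a 1.1-fold lower number from compound 1 to compound 3 (0.05 log units; within the scatter) and a 1.7-fold lower number from compound 2 to compound 3 (0.22 log units; within the scatter). Compound 4 `NC(=O)[C@@H](CCC(F)(F)F)N(C[C@@H]1CCO1)S(=O)(=O)c1ccc(Cl)cc1` has not been measured; relative to compound 2 the change is oxetan-2-yl in place of 3,3-dimethyloxetan-2-yl on a saturated chain carbon bound to a sulfonamide nitrogen. Given that a 1.7-fold lower number from compound 2 to compound 3 (0.22 log units; within the scatter) and the other two ring swaps all stayed within the scatter, the expected step for compound 4 is a 1.4-fold lower number from compound 2 to compound 4 (0.14 log units; within the scatter), nothing beyond the scatter. Compound 4 is therefore estimated at about 16 10^-6 cm/s, with a likely range from 8 10^-6 cm/s to 30 10^-6 cm/s.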

Compound 4, apparent permeability: 34.9 10^-6 cm/s
The estimate for compound 4 lay 2.2-fold (0.34 log units) below the measured number; the whole stated range lies below it.
By their numbers in this assay, from the lowest: compounds 3, 1, 2 and 4 (each within the scatter of the next, the first and the last beyond it).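

In this assay this position now shows steps beyond the scatter: oxetan-2-yl in place of oxan-2-yl gives a 2.6-fold higher number from compound 3 to compound 4 (0.42 log units; beyond the scatter) and in place of 4,4-dimethyloxetan-2-yl gives a 2.3-fold higher number from compound 1 to compound 4 (0.37 log units; beyond the scatter) on the same chain carbon. Compound 2 goes against any simple rule favouring oxetan-2-yl, since removing its 3,3-dimethyl pattern gives only a 1.6-fold higher number from compound 2 to compound 4 (0.19 log units; within the scatter) and stays within the scatter. Nothing at hand explains these steps. The compounds shown leave open how an amine, a carboxylic acid or a longer chain in place of these rings would read at this position.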